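This account rests on a few compounds, and the source may have more. Where it says the series, first, only, none or still open, it means among the compounds named here.

Compound 1, with structure `Fc1ccc(C2(c3ccc(F)cc3)CNC(c3cccc(Cl)c3)=N2)cc1`, is the reference point of this series. In an assay on LM cells for displacement of a labelled ligand from Neuropeptide Y receptor type 5 (Homo sapiens) (a higher number here means a weaker inhibitor, a lower number a stronger inhibitor), compound 1 gives 5.4 nM, the lowest of the three numbers recorded, and both other compounds lie beyond the scatter from it. Compound 2, `CC(=O)c1cccc(C2=NC(c3ccc(F)cc3)(c3ccc(F)cc3)CN2)c1`, gives 44 nM in this assay; compound 3, `OCc1cccc(C2=NC(c3ccc(F)cc3)(c3ccc(F)cc3)CN2)c1`, gives 59 nM. The two steps away from compound 1 are an 8.1-fold higher number from compound 1 to compound 2 (0.91 log units; beyond the scatter) and an 11-fold higher number from compound 1 to compound 3 (1.04 log units; beyond the scatter), while between the two weaker compounds the step is a 1.3-fold higher number from compound 2 to compound 3 (0.13 log units; within the scatter).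

Compound 4, `N#Cc1cc(C2=NC(c3ccc(F)cc3)(c3ccc(F)cc3)CN2)ccn1`, has not yet been measured. Relative to compound 1 the change is 2-cyanopyridin-4-yl in place of 3-chlorophenyl on a carbon with a double bond to nitrogen. Both measured steps that start from compound 1 touch the same aromatic carbon that bears the chloro group, and each produced a clear loss of potency; here the whole 3-chlorophenyl ring leaves, so a loss of comparable or somewhat larger size is expected in this assay. Compound 4 is therefore estimated at 60 nM, within a range of 15 nM to 250 nM, corresponding to an expected step of an 11-fold higher number from compound 1 to compound 4 (1.05 log units; beyond the scatter).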

Compound 4, half-maximal inhibitory concentration: 4.8 nM
Beside the measured number, compound 4's estimate is 13-fold (1.10 log units) above it; measured number outside the range, below it.
By their numbers in this assay, from the lowest: compounds 4 and 1 (each within the scatter of the next); then compounds 2 and 3 (each within the scatter of the next).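

In this assay, the carbon between two ring nitrogen atoms accepts the exchange of the entire aromatic ring, since 2-cyanopyridin-4-yl in place of 3-chlorophenyl gives no change beyond the scatter (a 1.1-fold lower number from compound 1 to compound 4 (0.05 log units; within the scatter)). The earlier compounds shown here showed only losses, and here the same new ring stands clearly apart from 3-acetylphenyl (a 9.2-fold lower number from compound 2 to compound 4 (0.96 log units; beyond the scatter)) and from 3-(hydroxymethyl)phenyl (a 12-fold lower number from compound 3 to compound 4 (1.09 log units; beyond the scatter)). Among these four compounds, then, the 3-chlorophenyl group is not the only ring that gives a low number.

Going by these compounds, whether the nitrile or the ring nitrogen counts for more stays open, and a 3-cyanophenyl or a pyridin-4-yl group at this carbon would separate the two. The effect of an amine on this ring is also open, and no available evidence explains why the new ring matches the 3-chlorophenyl group.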